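Shifting the fluorine on the aryl ring of compound 2

A few compounds are considered here, and "the series" means these few. Any claim that something is new, unique, unknown or untested is made for them only; others in the source may bear on it.

Measured so far:
compound 1 `COc1ccc2[nH]c(-c3cccc(F)c3)cc(=O)c2c1OC` — 2600 nM
compound 2 `COc1ccc2[nH]c(-c3ccccc3F)cc(=O)c2c1O` — 50 nM

In a functional assay on Hep 3B2 cells (Homo sapiens) for cytotoxicity, read by MTT assay, with a stated time of 48 h (a higher number here means a weaker inhibitor, a lower number a stronger inhibitor), compound 2 gives 50 nM, the lowest of the two numbers recorded. Compound 1 gives 2600 nM in this assay, a gap well beyond the scatter. Compound 3 `COc1ccc2[nH]c(-c3cccc(F)c3)cc(=O)c2c1O` awaits measurement; it differs from compound 2 in one place: 3-fluorophenyl in place of 2-fluorophenyl on an aromatic carbon. Compound 1 and compound 2 differ at more than one point, so their gap cannot be assigned to the fluorine position alone. A moderate step toward a higher number is expected, a 3.0-fold higher number from compound 2 to compound 3 (0.48 log units; beyond the scatter), with much uncertainty. Compound 3 is therefore estimated at 150 nM, within 30 nM to 900 nM.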

Compound 3, half-maximal inhibitory concentration: 70 nM
The estimate for compound 3 lay 2.1-fold (0.33 log units) above the measured number; the range from low to high includes it.
By their numbers in this assay, from the lowest: compounds 2 and 3 (each within the scatter of the next); then compound 1.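

In this assay, 3-fluorophenyl in place of 2-fluorophenyl gives a 1.4-fold higher number from compound 2 to compound 3 (0.15 log units; within the scatter) and so does not separate the two fluorine placements on this aryl ring. Compound 1 now has a partner differing in one place: hydrogen in place of methyl on the oxygen gives a 37-fold lower number from compound 1 to compound 3 (1.57 log units; beyond the scatter) and places that large gap at the oxygen, not at the fluorine. Nothing available explains either step. Open, going by these compounds, are plain phenyl, or an amine or carboxylic acid on this ring, and the methyl ether carrying 2-fluorophenyl.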